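Swapping a bromobenzyl for a benzoylmethyl group

The source may hold more compounds than are shown below. What is called first, only, known or untested is meant among the compounds shown, and "the series" means these compounds.

The measured compounds, all in an ADME assay on GES1 cells (Homo sapiens) for inhibition, read by MTT assay, with a stated time of 72 h; on this read-out higher numbers stand for weaker inhibition and lower numbers for stronger inhibition:
Compound 1 `Cc1cc(Nc2cc(-c3ccccc3)[nH]n2)n2nc(SCc3cccc(Br)c3)nc2n1` gives > 50000 nM, which is a limit of the assay.
Compound 2 `Cc1cc(Nc2cc(-c3ccc(Cl)cc3)[nH]n2)n2nc(SCc3ccc(Br)cc3)nc2n1` gives 28200 nM.
Compound 3 `COc1ccc(Cn2ccc(Nc3cc(C)nc4nc(SCc5ccc(Br)cc5)nn34)n2)cc1` gives > 50000 nM, which is a limit of the assay.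

Compound 1 therefore has no exact number of its own: it sits at the limit of > 50000 nM in this assay, at which 2 of the 3 values shown sit, the same place as compound 3, while compound 2 is the only one of the three with a measured value, and that value already points to weak inhibition. For the measured compounds named here, no pair of these measured compounds differs in just one place, so no measured step is available to lean on.

Compound 4 `Cc1cc(Nc2cc(-c3ccccc3)[nH]n2)n2nc(SCC(=O)c3ccccc3)nc2n1` is the unmeasured partner of compound 1. The change between them is benzoyl in place of 3-bromophenyl on a saturated chain carbon bound to a sulfur.

With every measured compound showing weak inhibition in this assay, and with compound 1 at its limit, the expectation for compound 4 is a step of no size beyond the scatter, an at least 1.1-fold lower number from compound 1 to compound 4 (0.04 log units; that floor lies within the scatter). Compound 4 is estimated to give 45000 nM, with a range from 15000 nM to 120000 nM, and a fair chance that this assay again reports only a limit for it.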

Compound 4, half-maximal inhibitory concentration: 33300 nM
Beside the measured number, compound 4's estimate is 1.4-fold (0.13 log units) above it; the measured number falls inside the stated range.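

In this assay compound 1 gives > 50000 nM, which is a limit of the assay and not a number. Compound 4 gives a measured value at this position, and benzoyl in place of 3-bromophenyl on a saturated chain carbon bound to a sulfur makes for an at least 1.5-fold lower number from compound 1 to compound 4 (0.17 log units; that floor lies within the scatter), so this change brings in a carbonyl and a hydrogen-bond acceptor, takes out the bromine, and still leaves inhibition weak. The step has a floor but no exact size, because one of its two ends is a limit: the limit of > 50000 nM in this assay, at which 2 of the 4 values shown sit.

This single change alters several things at once, so the compounds shown cannot tell whether the carbonyl, the loss of the bromine or the extra heavy atom matters for the number. On these data alone, how the same place would respond to a plain benzyl group without bromine, to a longer chain, or to a chain ending in an amine or a carboxylic acid also remains open.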